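Replacing the Dichlorophenyl Group of Compound 2

The source may report more compounds than this note shows. Statements on the series, on what has been measured and on what is new or still open speak of the compounds shown alone.

In a functional assay on MCF7 cells (Homo sapiens) for cytotoxicity, read by MTT assay, with a stated time of 72 h (on this read-out lower numbers stand for stronger inhibition and higher numbers for weaker inhibition), compound 1 `COc1ccc(/C=C2\CCC/C(=C\c3ccccc3Cl)C2=O)cc1OC` gives 10400 nM, while compound 2 `COc1ccc(/C=C2\CCC/C(=C\c3ccc(Cl)cc3Cl)C2=O)cc1OC` gives 16200 nM. These two numbers are all that is measured so far, and compound 2 cannot be separated from compound 1 because a 1.6-fold higher number from compound 1 to compound 2 (0.19 log units; within the scatter) stays within the usual scatter. That step places chloro in place of hydrogen on an aromatic carbon.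

Compound 3 `COc1cc(/C=C2\CCC/C(=C\c3ccc(OC)c(OC)c3)C2=O)ccc1O` asks for a much larger change: 4-hydroxy-3-methoxyphenyl in place of 2,4-dichlorophenyl on a double-bonded chain carbon bound to a double-bonded ring carbon. In words, 4-hydroxy-3-methoxyphenyl takes the place of 2,4-dichlorophenyl on a double-bonded chain carbon bound to a double-bonded ring carbon. Among the measured compounds shown here, the one measured step is only a weak guide, since it swaps a single chloro for hydrogen. For the measured compounds named here, no measured compound carries the incoming group at this place, so the data cannot show which way the number might move. Going by the values given here, with a 1.6-fold higher number from compound 1 to compound 2 (0.19 log units; within the scatter) as the only evidence, no shift beyond the scatter is expected, though the uncertainty is wide. The expected step is a 1.6-fold lower number from compound 2 to compound 3 (0.21 log units; within the scatter). For compound 3, the estimated value is 10000 nM, with an expected range of 3000 nM to 30000 nM.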

Compound 3, half-maximal inhibitory concentration: 7900 nM
Compound 3: the middle estimate sits 1.3-fold (0.10 log units) above what was measured; the measured number falls inside the stated range.
By their numbers in this assay, from the lowest: compounds 3, 1 and 2 (each within the scatter of the next, the first and the last beyond it).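

In this assay, among the compounds shown here, this position takes the exchange of a whole substituted ring, and a 2.1-fold lower number from compound 2 to compound 3 (0.31 log units; beyond the scatter) is the first step to clear the scatter, although only modestly. The comparison with the 2-chlorophenyl group tells a different story: a 1.3-fold lower number from compound 1 to compound 3 (0.12 log units; within the scatter) stays within the scatter, so 4-hydroxy-3-methoxyphenyl and 2-chlorophenyl cannot be told apart here, and the difference appears only against 2,4-dichlorophenyl. Chlorine on this ring is therefore not needed to keep the number at the level of compound 1, but nothing available explains why the number shifts from compound 2 to compound 3.

The compounds shown do not separate the hydroxy group from the methoxy group of the incoming ring, so it stays open whether either one alone would give the same step. Going by these compounds, it also stays open how a phenyl ring carrying an amine or a carboxylic acid would read at this place, and whether any such ring could move the number further than this modest step.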